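The source may report more compounds than this note shows. Statements on the series, on what has been measured and on what is new or still open speak of the compounds shown alone.

Compound 1 `C/C(=N\O)c1ccc(NC(=O)Cn2nc(-c3ccc(Cl)cc3)nc2N)cc1`: 20.2%
Compound 2 `COc1cc(-c2nc(N)n(CC(=O)Nc3ccc(/C(C)=N\O)cc3)n2)cc(OC)c1OC`: 25.8%
Compound 3 `C/C(=N/O)c1ccc(NC(=O)Cn2nc(-c3ccccc3)nc2N)cc1`: 32%

Three compounds sharing one core were measured in a functional assay on A549 cells (Homo sapiens) for inhibition, read by sulforhodamine B assay, with a stated time of 48 h, tested at 10 uM; on this read-out lower numbers stand for less inhibition of growth and higher numbers for more inhibition of growth at the one concentration tested. Compound 1 gives 20.2%, the lowest of the three numbers shown, though compound 2 with 25.8% sits within the usual scatter of it, so the two cannot be told apart. Compound 3 with 32% lies beyond the scatter of compound 1, on the higher side. No pair of these compounds differs in only one place, so no single-point step is available from the measured set.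

Compound 4 `CC(=O)c1ccc(NC(=O)Cn2nc(-c3ccc(Cl)cc3)nc2N)cc1` is the unmeasured partner of compound 1. It differs from compound 1 as follows: a group of 3 heavy atoms (2 carbon, 1 oxygen; no ring) in place of a group of 4 heavy atoms (2 carbon, 1 nitrogen, 1 oxygen; no ring), on an aromatic carbon. The change is small in the count of heavy atoms and sits on the same aromatic carbon, para to a large group. Within the data shown here, with no measured step of this kind to lean on, the step of a number 1.8 percentage points higher from compound 1 to compound 4 (within the scatter) is expected to stay within the scatter, in no clear direction. Compound 4 is therefore estimated at 22%, between 8% and 36%.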

Compound 4, percent growth inhibition at one concentration: 22%
Compound 4: the middle estimate sits on the measured number at the digits printed, and the stated range covers the measured number.
By their numbers in this assay, from the lowest: compounds 1, 4, 2 and 3 (each within the scatter of the next, the first and the last beyond it).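

In this assay, the set now holds its first step in a single place: acetyl in place of the group of 4 heavy atoms, on an aromatic carbon para to a large group, gives a number 1.8 percentage points higher from compound 1 to compound 4 (within the scatter). On the core of compound 1, then, this exchange removes the hydrogen-bond donor of the leaving group and takes the hydrogen-bond acceptors from 2 to 1, yet the read-out does not leave the scatter. No measured evidence bears on this result.

From the compounds shown here alone, whether an amine, a carboxylic acid or a longer chain on this aromatic carbon would also stay within the scatter remains open. Going by these compounds, it is equally open whether acetyl would give a step of this size on compound 2 or compound 3, whose other parts differ from those of compound 1.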